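Lengthening the hydroxycarbamoyl chain of compound 2

The source may hold more compounds than are shown below. What is called first, only, known or untested is meant among the compounds shown, and "the series" means these compounds.

In a functional assay on HEL cells (Homo sapiens) for antiproliferative activity, read by CCK-8 assay, with a stated time of 48 h (on this read-out higher numbers stand for weaker inhibition and lower numbers for stronger inhibition), compound 1 `O=C(CCCCCCOc1ccc(-c2nnc(-c3ccccc3)s2)cc1)NO` returns only a limit, > 10000 nM. Within the data shown here, compound 2 `O=C(CCCCOc1cccc(-c2nnc(-c3ccccc3)s2)c1)NO` gives 570 nM, the only actual number so far in this short series. Compound 3 `O=C(CCCCCOc1cccc(-c2nnc(-c3ccccc3)s2)c1)NO` differs from compound 2 thus: (hydroxycarbamoyl)methyl in place of hydroxycarbamoyl on a saturated chain carbon, four bonds along the chain from an oxygen on an aromatic ring, with (hydroxycarbamoyl)methyl in place of hydroxycarbamoyl on a saturated chain carbon, four bonds along the chain from an oxygen on an aromatic ring. Among the measured compounds shown here, no measured step in this assay gives the size of this change, so no shift beyond the scatter is expected, and neither direction is favoured. The expected step of a 1.1-fold lower number from compound 2 to compound 3 (0.06 log units; within the scatter) is small. For compound 3 the estimate is 500 nM, with an expected range of 150 nM to 1800 nM.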

Compound 3, half-maximal inhibitory concentration: 280 nM
For compound 3 the middle estimate is 1.8-fold (0.25 log units) above the measured one, within the range that was stated.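

In this assay, among these compounds, this chain position accepts (hydroxycarbamoyl)methyl in place of hydroxycarbamoyl, and the series gains its only readable step, of modest size (a 2.0-fold lower number from compound 2 to compound 3 (0.31 log units; beyond the scatter)). On this one step, the longer chain on a saturated chain carbon costs no antiproliferative activity. Compound 1 gives only a limit, and steps to it cannot be read: the limit of > 10000 nM in this assay, at which 1 of the 3 values shown sits.

As far as these compounds go, whether a still longer chain on the core of compound 3 keeps this gain remains open. So does whether a carboxylic acid in place of the hydroxycarbamoyl group retains any activity.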